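The compounds below may be only part of what the source reports. "The series", "measured", "known", "first", "only" and "open" are said of these compounds alone.

Measured compounds in an assay on cells for activation of Cystic fibrosis transmembrane conductance regulator (Homo sapiens), read by fluorescence, with a stated time of 10 min; a lower number here means that less compound is needed, a higher number that more compound is needed for the effect:
compound 1, `O=c1c(-c2cccc([N+](=O)[O-])c2)nc2ccccc2n1Cc1ccccc1`, compound 1 gives 9 nM.
compound 2, `O=c1[nH]c2ccccc2nc1-c1cccc([N+](=O)[O-])c1`, compound 2 reaches only the limit of this assay, > 10000 nM.

For the measured compounds named here, compound 2 thus sits at the limit of > 10000 nM in this assay, at which 1 of the 2 values shown sits, the only one of the pair without a number. Going by the values given here, the single measured step is an at least 1100-fold higher number from compound 1 to compound 2 (3.04 log units; beyond the scatter). Compound 3, `Cn1c(=O)c(-c2cccc([N+](=O)[O-])c2)nc2ccccc21`, differs from compound 2 by methyl in place of hydrogen on an aromatic nitrogen. Methyl restores a substituent on that nitrogen, but a far smaller one than the benzyl that the benzyl-to-hydrogen step removed, so only a partial reversal is expected. Compound 3 is estimated at 2000 nM, between 300 nM and 10000 nM, an expected step of an at least 5.0-fold lower number from compound 2 to compound 3 (0.69 log units; beyond the scatter).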

Compound 3, half-maximal effective concentration: > 10000 nM
Compound 3 gave a limit, no number; the forecaster's own chance of this, stated with the estimate: 40%; middle value at least 5.0-fold (0.69 log units) away from the limit.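

In this assay compound 3 gives only a limit (> 10000 nM) and no number. Cutting benzyl back to methyl gives an at least 1100-fold higher number from compound 1 to compound 3 (3.04 log units; beyond the scatter) and so shows that a substituent on this aromatic nitrogen is not enough by itself to give a number. The step from compound 2 to compound 3 cannot be read, and both compounds without benzyl now rest at the limit: the limit of > 10000 nM in this assay, at which 2 of the 3 values shown sit.

As far as these compounds go, how much of the benzyl is needed stays open. An ethyl, a longer chain or a phenyl placed directly on that nitrogen could still give a number or stay at the limit.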